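The compounds below may be only part of what the source reports. "The series", "measured", "known", "first", "only" and "open" are said of these compounds alone.

Cell-killing tests are a common first screen for small molecules, and here three compounds sharing one core have numbers in a functional assay on HepG2 cells (Homo sapiens) for cytotoxicity, read by MTT assay, with a stated time of 24 h; a lower number here means a stronger inhibitor, a higher number a weaker inhibitor. Compound 1 `CN1C/C(=C\c2cccnc2)C(=O)/C(=C/c2ccccc2F)C1` gives 4810 nM. Compound 3 `CN1C/C(=C\c2ccncc2)C(=O)/C(=C/c2ccccc2F)C1` gives 4600 nM, which is level with compound 1 within the scatter. Compound 2 `CN1C/C(=C\c2ccc(C#N)cc2)C(=O)/C(=C/c2cccnc2)C1` gives 12700 nM, the highest number of the three, so compound 1 sits at the lower end of this small set alongside compound 3.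

Compound 4 `O=C1/C(=C/c2cccnc2)CN(S(=O)(=O)c2ccc(Cl)cc2)C/C1=C\c1ccccc1F` has not yet been measured. Its difference from compound 1 is (4-chlorophenyl)sulfonyl in place of methyl on an amine nitrogen in a ring.

Two measured steps show how far the number has moved so far: a 2.6-fold higher number from compound 1 to compound 2 (0.42 log units; beyond the scatter) is modest, and a 1.0-fold lower number from compound 1 to compound 3 (0.02 log units; within the scatter) stays within the scatter. Among the compounds with values here, both changes sit on a double-bonded chain carbon, so neither tests the amine nitrogen, and no measured compound carries anything but methyl there. The direction therefore cannot be read from these data, and the small size of those two steps is only a weak guide. The expected change is a 1.2-fold lower number from compound 1 to compound 4 (0.08 log units; within the scatter), which means no shift beyond the scatter, held with wide uncertainty on both sides. For compound 4 the estimated value is 4000 nM, with an expected range from 1200 nM to 13000 nM.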

Compound 4, half-maximal inhibitory concentration: 12400 nM
Compound 4: middle estimate off by 3.1-fold (0.49 log units), on the low side; the range from low to high includes it.
By their numbers in this assay, from the lowest: compounds 3 and 1 (each within the scatter of the next); then compounds 4 and 2 (each within the scatter of the next).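

Within the data shown here, compound 4 is the only compound here with anything other than methyl on the amine nitrogen in the ring, and in this assay this single change gives a 2.6-fold higher number from compound 1 to compound 4 (0.41 log units; beyond the scatter) in a comparison where the rest of the molecule stays the same. This shows that the position is not silent: the number moves beyond the scatter, towards a weaker inhibitor, so this nitrogen can influence the result in this cell test. The entering (4-chlorophenyl)sulfonyl group brings a sulfonyl unit, a chlorine and an aromatic ring together, and nothing available here explains the shift or assigns it to any one of those parts.

The compounds shown leave open which part of the new group carries the change: an unsubstituted phenylsulfonyl would test the chlorine, while a benzyl group would keep an aromatic ring without the sulfonyl. They also leave open whether a small group such as ethyl or acetyl on the same nitrogen would move the number at all, or in which direction.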